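A few compounds are considered here, and "the series" means these few. Any claim that something is new, unique, unknown or untested is made for them only; others in the source may bear on it.

Working notes on the series.

The shared core of compound 1 `O=C([C@H]1CC2CCC1C2)N1CC(c2nc(-c3ccccc3)no2)C1` is the reference point. In an assay on HEK293 cells for positive allosteric modulation of metabotropic glutamate receptor 5 (Homo sapiens), read by FLIPR (on this read-out higher numbers stand for an effect only at larger amounts of compound and lower numbers for an effect already at smaller amounts), compound 1 gives 120 nM. On the two numbers in hand compound 1 carries the higher one; its nearest neighbour is compound 2 `O=C([C@H]1CC2CCC1C2)N1CC(c2nc(-c3cccc(Cl)c3)no2)C1`, which in this assay gives 74 nM. Among the compounds with values here, the only step so far, a 1.6-fold lower number from compound 1 to compound 2 (0.21 log units; within the scatter), comes from a chloro in place of hydrogen on an aromatic carbon and is too small to be read as a real change.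

Compound 3 `O=C([C@@H]1CC2CCC1C2)N1CC(c2nc(-c3ccccc3)no2)C1` is the not yet measured partner. Compared with compound 1 it differs as follows: the two compounds have the same atoms and bonds; at least one stereo element is drawn with a configuration in one of them and without one in the other: 1 of 3 stereo elements differ; a stereocentre at a saturated ring carbon is drawn S in compound 1 and R in compound 3. Within the data shown here, no measured pair touches a stereocentre, so the single step that exists does not bear on this change; the aromatic substitution it describes is unrelated to the configuration at the saturated ring carbon. The direction of the effect therefore cannot be read from the data. Because compound 1 sits at 120 nM and a change of configuration at a saturated ring carbon may move the number in either direction, compound 3 is expected at 300 nM in this assay, with a range from 80 nM to 2000 nM. This estimate corresponds to a step of a 2.5-fold higher number from compound 1 to compound 3 (0.40 log units; beyond the scatter).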

Compound 3, half-maximal effective concentration: 400 nM
Compound 3: the middle estimate sits 1.3-fold (0.12 log units) below what was measured; low and high end bracket the measured number.
By their numbers in this assay, from the lowest: compounds 2 and 1 (each within the scatter of the next); then compound 3.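

Configuration at the saturated ring carbon gives the first step in the series that lies beyond the scatter in this assay: a 3.3-fold higher number from compound 1 to compound 3 (0.52 log units; beyond the scatter), with the lower number on compound 1, drawn S at this stereocentre. Within the data shown here, the two compounds have the same atoms and bonds, so this step isolates a change at the stereocentre, whereas the only earlier step, a 1.6-fold lower number from compound 1 to compound 2 (0.21 log units; within the scatter), involved a chloro in place of hydrogen on an aromatic carbon and stayed within the scatter. One reservation applies to reading the step as a clean exchange between two configurations: the fact that one of compounds 1 and 3 is drawn with a defined configuration and the other without, at the place where they differ

As far as these compounds go, whether the step from S to R at this stereocentre has the same direction and size when the chloro of compound 2 is present remains open. Also open, from the compounds shown here alone, is how the number in this assay would respond to an amine or a carboxylic acid at the saturated ring carbon, and whether either group would make the configuration there matter more or less.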